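A Methyl Added to a Weakly Cytotoxic Acrylamide

The source may report more compounds than this note shows. Statements on the series, on what has been measured and on what is new or still open speak of the compounds shown alone.

Compound 1 `C/C(=C\c1cc(-c2ccc(F)cc2)cs1)C(N)=O`: 20800 nM
Compound 2 `C/C(=C\c1cccc(-c2ccccc2)c1)C(N)=O`: 15700 nM

In a functional assay on HeLa cells (Homo sapiens) for cytotoxicity, read by CCK-8 assay, with a stated time of 24 h (on this read-out higher numbers stand for weaker inhibition and lower numbers for stronger inhibition), compound 1 gives 20800 nM and compound 2 gives 15700 nM. Compound 2 has the lower of the two numbers, but its gap to compound 1 lies within the scatter, so the two compounds cannot be told apart on this read-out, and neither is to be called the stronger one. Both numbers show only weak inhibition of the cells.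

Compound 3 `C/C(=C\c1cccc(-c2ccc(C)cc2)c1)C(N)=O` differs from compound 2 by methyl in place of hydrogen on an aromatic carbon. For the measured compounds named here, no pair of measured compounds shares this change, so there is no measured step to lean on. Both measured compounds sit in the same weak range, and the change is a single small group. The step from compound 2 to compound 3 is expected to be a 1.1-fold lower number from compound 2 to compound 3 (0.05 log units; within the scatter), that is, nothing beyond the scatter. Compound 3 is accordingly estimated at 14000 nM, with a range from 6000 nM to 35000 nM.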

Compound 3, half-maximal inhibitory concentration: 24800 nM
For compound 3 the middle estimate is 1.8-fold (0.25 log units) below the measured one, within the range that was stated.
By their numbers in this assay, from the lowest: compounds 2, 1 and 3 (each within the scatter of the next).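

In this assay, for the compounds shown here, the step for methyl in place of hydrogen on an aromatic carbon, para to a large group, is a 1.6-fold higher number from compound 2 to compound 3 (0.20 log units; within the scatter) and gives the first measured reading of a change at this position. On this evidence, a single methyl at this place does not separate the two compounds, and the shared core stays in the same weak range. No measurement shown here bears on the cause of this result.

On these data alone, whether a different group at the same carbon, such as an amine, a carboxylic acid or a longer chain, would shift the number beyond the scatter remains open. Also open, as far as these compounds go, is whether methyl would give a similar result at another carbon of this ring or on the core of compound 1.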